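A few compounds are considered here, and "the series" means these few. Any claim that something is new, unique, unknown or untested is made for them only; others in the source may bear on it.

Of the compounds shown here, three built on one shared core have been tested in a functional assay on BaF3 cells (Mus musculus) for antiproliferative activity, read by CCK-8 assay and cell counting, with a stated time of 76 h; a higher number here means a weaker inhibitor, a lower number a stronger inhibitor. Compound 1 `COc1cc2nccc(Oc3ccc(Nc4nn(C)cc4C(=O)NC45CCC(CC4)CC5)cc3)c2cc1C(N)=O` gives only a limit of the assay, > 10000 nM. Compound 2 `COc1cc2nccc(Oc3ccc(Nc4nn(C)cc4C(=O)N4CCCCC4)cc3)c2cc1C(N)=O` gives 5650 nM, and compound 3 `COc1cc2nccc(Oc3ccc(Nc4nn(C)cc4C(=O)NC4CCCCCCC4)cc3)c2cc1C(N)=O` gives 3210 nM. Of the two plain numbers compound 2 has the higher, and the gap to compound 3, a 1.8-fold lower number from compound 2 to compound 3 (0.25 log units; within the scatter), lies within the scatter; the step of an at least 1.7-fold lower number from compound 1 to compound 2 (0.24 log units; that floor lies within the scatter) rests on a limit. Compound 4 `COc1cc2nccc(Oc3ccc(Nc4nn(C)cc4C(=O)NCC4CCCCC4)cc3)c2cc1C(N)=O` is not yet measured; it differs from compound 2 in that ((cyclohexylmethyl)amino in place of piperidin-1-yl on a carbonyl carbon). The closest guide is a 1.8-fold lower number from compound 2 to compound 3 (0.25 log units; within the scatter), where a carbon ring on an amide-type nitrogen likewise replaced piperidin-1-yl, so little change beyond the scatter is expected. Compound 4 is estimated at 3500 nM (1500 nM to 8500 nM), a step of a 1.6-fold lower number from compound 2 to compound 4 (0.21 log units; within the scatter).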

Compound 4, half-maximal inhibitory concentration: > 10000 nM
Compound 4 gave a limit, no number; the forecaster's own chance of this, stated with the estimate: 10%; middle value at least 2.8-fold (0.45 log units) away from the limit.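

Compound 4 gives only a limit of the assay, not a number: the limit of > 10000 nM in this assay, at which 2 of the 4 values shown sit. Cyclohexylmethyl in place of cyclooctyl on an amide-type nitrogen gives an at least 3.1-fold higher number from compound 3 to compound 4 (0.49 log units; beyond the scatter), so a carbon ring on this nitrogen does not by itself keep the number near that of compound 3, while the change from piperidin-1-yl gives an at least 1.7-fold higher number from compound 2 to compound 4 (0.24 log units; that floor lies within the scatter). The step between compound 1 and compound 4 cannot be read, as both are limits.

As far as these compounds go, whether a group carrying an amine or a carboxylic acid on this carbonyl carbon would give a lower number remains open.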